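The source may hold more compounds than are shown below. What is called first, only, known or untested is meant among the compounds shown, and "the series" means these compounds.

Compound 3 `O=C(COc1ccc(/C=C2\SC(=S)N(c3ccc([N+](=O)[O-])cc3)C2=O)cc1)Nc1ccc(C(=O)O)cc1` stands at the edge of what the numbers shown can resolve. In an assay on isolated protein for inhibition of Apoptosis regulator Bcl-2 (Homo sapiens), read by fluorescence polarization (on this read-out higher numbers stand for weaker inhibition and lower numbers for stronger inhibition), compound 3 gives > 10000 nM, which is a limit of the assay and not a number. Compound 2 `O=C(O)c1ccc(COc2ccc(/C=C3\SC(=S)N(c4ccc([N+](=O)[O-])cc4)C3=O)cc2)cc1` likewise returns only a limit in this assay, > 10000 nM. Between these two compounds lies a step that the two limits leave unreadable from compound 2 to compound 3, and the limit of > 10000 nM in this assay, at which 2 of the 3 values shown sit, is the point at which both of their values sit. Going by the values given here, the one compound with a number is compound 1 `O=C(O)c1ccc([N+](=O)[O-])c(COc2ccc(/C=C3\SC(=S)N(c4ccccc4)C3=O)cc2)c1`, which in this assay gives 9000 nM.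

Compound 4 `O=C(O)c1ccc([N+](=O)[O-])c(COc2ccc(/C=C3\SC(=S)N(c4ccc([N+](=O)[O-])cc4)C3=O)cc2)c1` differs from compound 3 by 5-carboxy-2-nitrophenyl in place of (4-carboxyphenyl)carbamoyl on a saturated chain carbon bound to an oxygen on an aromatic ring. At that place compound 4 carries the same group as compound 1. Among the compounds with values here, no measured step covers this exchange directly: the only step between compounds differing in one place is unreadable, and compound 1 and compound 2 differ in two places at once, so their two values can merely be set side by side. On this footing compound 4 is expected to remain close to the limit, with a step that the limit leaves unreadable from compound 3 to compound 4 that is not expected to go beyond the scatter. The estimate for compound 4 in this assay is 12000 nM, in the range 4000 nM to 40000 nM, with a fair chance that only a limit is reported.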

Compound 4, inhibition constant: 3100 nM
For compound 4 the middle estimate is 3.9-fold (0.59 log units) above the measured one, outside the stated range (below it).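

With the rest of the structure held fixed, the group on a saturated chain carbon bound to an oxygen on an aromatic ring now gives a readable change in this assay: 5-carboxy-2-nitrophenyl produces an at least 3.2-fold lower number from compound 3 to compound 4 (0.50 log units; beyond the scatter) and an at least 3.2-fold lower number from compound 2 to compound 4 (0.50 log units; beyond the scatter). These two steps give only a minimum size and the exchange between compound 2 and compound 3 remains unreadable, with the values of both compounds being limits of the assay and not numbers: the limit of > 10000 nM in this assay, at which 2 of the 4 values shown sit. Going by these compounds alone, the other place also becomes readable, as nitro in place of hydrogen on an aromatic carbon gives a 2.9-fold lower number from compound 1 to compound 4 (0.46 log units; beyond the scatter), the only new step with a number at both ends.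

Which part of 5-carboxy-2-nitrophenyl carries the change stays open, as both compounds shown with that group, compound 1 and compound 4, hold its nitro and its carboxylic acid together. The compounds shown also do not tell whether an amine in place of that nitro, or a methyl ester in place of that carboxylic acid, would keep the number of compound 4.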